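Dropping the Butyl Chain from an Aryl-Isoxazole Nucleoside

The compounds below may be only part of what the source reports. "The series", "measured", "known", "first", "only" and "open" are said of these compounds alone.

Measured compounds:
- Compound 1, `CCCCc1ccc(-c2cc(-c3cn([C@H]4C[C@H](OC(C)=O)[C@@H](COC(C)=O)O4)c(=O)[nH]c3=O)on2)cc1`: 97.4%
- Compound 2, `CCCCCCCCc1cc(-c2cn([C@H]3C[C@H](O)[C@@H](CO)O3)c(=O)[nH]c2=O)on1`: 120%
- Compound 3, `O=c1[nH]c(=O)n([C@H]2C[C@H](O)[C@@H](CO)O2)cc1-c1cn(Cc2ccccc2)nn1`: 97.5%

All three compounds share a nucleoside core carrying a heterocyclic arm, and all were tested in a functional assay on NCI-H23 cells (Homo sapiens) for cytotoxicity, read by sulforhodamine B assay, tested at 10 uM; on this read-out lower numbers stand for less inhibition and higher numbers for more inhibition at the one concentration tested (going by the name of the read-out). Compound 1 sits at the lowest of the three numbers, but its neighbour compound 3 lies within the scatter of it, so the two cannot be told apart. Compound 2, the one with the octyl chain and the free diol, stands beyond the scatter above compound 1.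

Compound 4, `CC(=O)OC[C@H]1O[C@@H](n2cc(-c3cc(-c4ccccc4)no3)c(=O)[nH]c2=O)C[C@@H]1OC(C)=O`, is the compound not yet measured. It differs from compound 1 in one place: hydrogen in place of butyl on an aromatic carbon. Cut one bond further out, the change reads 4-butylphenyl to phenyl. Within the data shown here, no pair of measured compounds shows this kind of step, so its size must be estimated without a direct precedent.

In this assay the step from compound 1 to compound 4 is expected to be a modest decrease, a number 12.4 percentage points lower from compound 1 to compound 4 (beyond the scatter), that may or may not exceed the scatter. Compound 4 is therefore expected to give 85%, within a range from 55% to 105%.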

Compound 4, a percentage reported as inhibition, at one concentration (the size of the read-out at that concentration, not a potency): 91.4%
For compound 4 the middle estimate is 6.4 percentage points below the measured one; measured number inside the range.
By their numbers in this assay, from the lowest: compounds 4, 1 and 3 (each within the scatter of the next); then compound 2.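

In this assay, among these compounds, trading the butyl chain for hydrogen on the six-membered aromatic ring gives a number 6 percentage points lower from compound 1 to compound 4 (within the scatter) and so offers the first direct reading of this position. At the one concentration tested, the butyl chain is therefore not required for the inhibition seen, and phenyl cannot be told apart from 4-butylphenyl. This is a reading at a single concentration rather than a potency, so a difference between the two compounds at other concentrations is not ruled out, and no available evidence accounts for the outcome.

Compounds 2 and 3 differ from compound 4 in more than one place, so their steps to it cannot be read, and the contribution of the two acetyl esters, which those compounds lack, stays unresolved. Also open, on these data alone, is what this assay would show with an amine, a carboxylic acid or a chain longer than butyl on that same aromatic carbon, and with free hydroxyl groups in place of the acetyl esters on the core of compound 4.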